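The compounds below may be only part of what the source reports. "The series", "measured", "known", "first", "only" and "open" are said of these compounds alone.

Measured compounds in a functional assay on A549 cells (Homo sapiens) for inhibition, read by MTT assay, with a stated time of 24 h; a lower number here means a stronger inhibitor, a higher number a weaker inhibitor:
- Compound 1 `CC1(C)[C@H]2CC[C@]1(C)N(Cc1cn(-c3ccc(Cl)cc3)nn1)C(=O)C2` gives 70 nM.
- Compound 2 `Cc1ccc(-n2cc(CN3C(=O)C[C@@H]4CC[C@@]3(C)C4(C)C)nn2)cc1` gives 400 nM.
- Compound 3 `CC1(C)[C@H]2CC[C@]1(C)N(Cc1cn(-c3ccccc3Br)nn1)C(=O)C2` gives 130 nM.

Compound 3 stands second highest of the three numbers in this assay. Its nearest neighbour is compound 1, reached by a 1.9-fold higher number from compound 1 to compound 3 (0.27 log units; within the scatter); its furthest is compound 2, from which a 3.1-fold lower number from compound 2 to compound 3 (0.49 log units; beyond the scatter) leads to compound 3.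

Compound 4 `CC1(C)[C@H]2CC[C@]1(C)N(Cc1cn(-c3cccc(O)c3)nn1)C(=O)C2` differs from compound 3 in one place: 3-hydroxyphenyl in place of 2-bromophenyl on an aromatic nitrogen.

Both measured steps that change the aryl group on the ring nitrogen bear on this. The swap a 1.9-fold higher number from compound 1 to compound 3 (0.27 log units; within the scatter) stayed within the scatter, while a 3.1-fold lower number from compound 2 to compound 3 (0.49 log units; beyond the scatter) and a 5.7-fold higher number from compound 1 to compound 2 (0.76 log units; beyond the scatter) were modest. For the measured compounds named here, no measured compound carries a 3-hydroxyphenyl group, so the data give no direct guide for the hydroxyl, and the three values span a modest range. A step of about a 1.5-fold higher number from compound 3 to compound 4 (0.19 log units; within the scatter) toward a somewhat higher number is therefore expected, with wide uncertainty. Compound 4 is estimated at 200 nM, most likely between 70 nM and 600 nM.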

Compound 4, half-maximal inhibitory concentration: 180 nM
Beside the measured number, compound 4's estimate is 1.1-fold (0.05 log units) above it, and the stated range covers the measured number.
By their numbers in this assay, from the lowest: compounds 1, 3 and 4 (each within the scatter of the next, the first and the last beyond it); then compound 2.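

Placing 3-hydroxyphenyl on the aromatic nitrogen, which brings 1 hydrogen-bond donor and 1 hydrogen-bond acceptor where 2-bromophenyl has neither, gives a 1.4-fold higher number from compound 3 to compound 4 (0.14 log units; within the scatter) in this assay, so this exchange does not separate the two compounds. The same group does stand apart from the two para-free comparisons only in part: the change from 4-methylphenyl gives a 2.2-fold lower number from compound 2 to compound 4 (0.35 log units; beyond the scatter), and the change from 4-chlorophenyl gives a 2.6-fold higher number from compound 1 to compound 4 (0.41 log units; beyond the scatter). For the compounds shown here, compound 4 therefore falls inside the range the earlier compounds set, and compound 2 remains the weakest of the four.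

No measurement shown accounts for these differences. As far as these compounds go, what an amine, a methoxy group or a carboxylic acid on the phenyl ring would give in place of the hydroxyl remains open.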